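Swapping triazole for imidazole on a pyrazoline core

The source may hold more compounds than are shown below. What is called first, only, known or untested is meant among the compounds shown, and "the series" means these compounds.

Compound 1 `CN(C)c1ccc(C2CC(c3ccc(-n4cncn4)cc3)=NN2C(=O)c2ccc(F)cc2)cc1` was tested in a functional assay on MDA-MB-231 cells (Homo sapiens) for inhibition, read by sulforhodamine B assay, tested at 10 uM (on this read-out lower numbers stand for less inhibition and higher numbers for more inhibition at the one concentration tested (going by the name of the read-out)), where compound 1 gives 12.5%. Of the two numbers available, this is the highest; the nearest is compound 2 `CN(C)c1ccc(C2CC(c3ccc(-n4cncn4)cc3)=NN2S(=O)(=O)c2ccc(Br)cc2)cc1`, which in this assay gives 10.4%. The step of a number 2.1 percentage points lower from compound 1 to compound 2 (within the scatter) changes the group on the ring nitrogen and lies within the scatter. Compound 3 `CN(C)c1ccc(C2CC(c3ccc(-n4ccnc4)cc3)=NN2C(=O)c2ccc(F)cc2)cc1` differs from compound 1 at a different place: 1H-imidazol-1-yl in place of 1H-1,2,4-triazol-1-yl on an aromatic carbon. Within the data shown here, no measured step touches this part of the shared core, so the only guide is that the one change made so far, a number 2.1 percentage points lower from compound 1 to compound 2 (within the scatter), left the read-out in this assay essentially unmoved. Compound 3 is therefore expected to show no step beyond the scatter, with a number 0.5 percentage points lower from compound 1 to compound 3 (within the scatter). In this assay compound 3 is estimated at 12%, in a range from 0% to 28%.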

Compound 3, a percentage reported as inhibition, at one concentration (the size of the read-out at that concentration, not a potency): 9.4%
Compound 3: the middle estimate sits 2.6 percentage points above what was measured; the measured number falls inside the stated range.
By their numbers in this assay, from the lowest: compounds 3, 2 and 1 (each within the scatter of the next).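

In this assay, among these compounds, the exchange of 1H-1,2,4-triazol-1-yl for 1H-imidazol-1-yl gives a number 3.1 percentage points lower from compound 1 to compound 3 (within the scatter) and so provides the first reading at this position, on an aromatic carbon para to a large group. On this read-out, the two five-membered aromatic rings, with 3 and 2 hetero atoms, cannot be told apart. Neither this exchange nor the one on the ring nitrogen moves the number beyond the scatter, and nothing available explains why the two rings read alike.

From the compounds shown here alone, it remains open whether a group of another kind at this position, such as an amine or a carboxylic acid, would move the number beyond the scatter. Also open, going by these compounds, is whether 1H-imidazol-1-yl would read the same alongside (4-bromophenyl)sulfonyl on the ring nitrogen.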